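Adding a Fluoro to Compound 3: What to Expect

A few compounds are considered here, and "the series" means these few. Any claim that something is new, unique, unknown or untested is made for them only; others in the source may bear on it.

Compound 1, `CC(C)S(=O)(=O)N1CCN(c2cnn(-c3cccc(F)c3)c(=O)c2OC2CCCC2)CC1`, gives 670 ng.h/mL in an ADME assay on the whole organism for pharmacokinetics, with Rattus norvegicus as the target, with a stated time of 6 h, at a dose of 10 mg/kg by the oral route; a higher number here means more compound in the circulation at the dose given, a lower number less compound in the circulation.
Compound 2, `CC(C)S(=O)(=O)N1CCN(c2cnn(-c3cccc(F)c3)c(=O)c2OC2CCC(F)C2)CC1`, gives 300 ng.h/mL in this assay.
Compound 3, `CC(C)S(=O)(=O)N1CCN(c2cnn(-c3cccc(Cl)c3)c(=O)c2OC2CCCC2)CC1`, gives 490 ng.h/mL in this assay.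

Compound 3 sits close to the other two: its gap to compound 1 and its gap to compound 2 are both within the usual scatter, so the three numbers cannot be ranked with confidence. Compound 4, `CC(C)S(=O)(=O)N1CCN(c2cnn(-c3cc(F)cc(Cl)c3)c(=O)c2OC2CCCC2)CC1`, has not yet been measured in this assay. It differs from compound 3 by fluoro in place of hydrogen on an aromatic carbon, with the fluoro entering meta to the chloro group on the six-membered aromatic ring of carbon only.

For the measured compounds named here, two measured steps bear on this. The step of a 2.2-fold lower number from compound 1 to compound 2 (0.35 log units; beyond the scatter) adds a fluoro, but on a saturated ring carbon, not an aromatic one. The step of a 1.4-fold lower number from compound 1 to compound 3 (0.14 log units; within the scatter) changes a halogen on the aromatic ring and stays within the scatter. Neither step repeats the present change exactly, so the expectation for compound 4 is a small step at most, perhaps a slight lowering, and the estimated step is a 1.2-fold lower number from compound 3 to compound 4 (0.09 log units; within the scatter). Compound 4 is estimated at 400 ng.h/mL, within the range 180 ng.h/mL to 900 ng.h/mL.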

Compound 4, area under the concentration-time curve: 490 ng.h/mL
Estimate against measurement, compound 4: 1.2-fold (0.09 log units) below, and the stated range covers the measured number.
By their numbers in this assay, from the lowest: compounds 2, 3, 4 and 1 (each within the scatter of the next, the first and the last beyond it).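

For the compounds shown here, compound 4 shows the effect of a fluoro on an aromatic carbon, where the earlier compounds showed it only on a saturated ring carbon. On the 3-chlorophenyl ring, this change gives no change at the digits printed from compound 3 to compound 4 (within the scatter) in this assay and so shows no measurable penalty at this position. Read from the other side, adding chloro to the fluorophenyl ring gives a 1.4-fold lower number from compound 1 to compound 4 (0.14 log units; within the scatter) and shows that carrying both halogens on the ring keeps the number within the scatter of either compound with a single halogen, but nothing shown here explains this result.

The compounds shown leave open whether a larger group on this same carbon, such as methoxy or trifluoromethyl, would hold the number as the fluoro does. They also leave open what an amine or a carboxylic acid there would do.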